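The source may hold more compounds than are shown below. What is called first, only, known or untested is meant among the compounds shown, and "the series" means these compounds.

Measured so far in a functional assay on SK-N-SH cells (Homo sapiens) for cytotoxicity, read by MTT assay, with a stated time of 24 h; a higher number here means a weaker inhibitor, a lower number a stronger inhibitor:
compound 1 `O=c1nc2ccc(Br)cn2cc1Cc1ccc(Cl)cc1` gives 940 nM;
compound 2 `O=c1nc2ccc(Cl)cn2cc1Cc1ccc(F)cc1` gives 9860 nM;
compound 3 `O=c1nc2ccc(Br)cn2cc1Cc1ccccc1` gives 137000 nM.

Compound 2 stands between the other two in this assay. The difference between its core and the core of compound 1 is not broken down here. Compound 4 `O=c1nc2ccccn2cc1Cc1ccc(F)cc1` has not been measured yet.

Going from compound 1 to compound 3, the change is hydrogen in place of chloro on an aromatic carbon, and the step it made was a 150-fold higher number from compound 1 to compound 3 (2.16 log units; beyond the scatter), a very weak result after the chloro is taken away.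

From compound 2 to compound 4, the change is hydrogen in place of chloro on an aromatic carbon. It is the same kind of change, but not the same: in compound 1 the chloro sits on a six-membered aromatic ring of carbon only, para to a large group, whereas in compound 2 it sits on a six-membered aromatic ring with one nitrogen, part of a fused system of two rings, two atoms from the ring nitrogen.

Because the only measured loss of a chloro, a 150-fold higher number from compound 1 to compound 3 (2.16 log units; beyond the scatter), was large, compound 4 is expected to be weaker than compound 2, with an estimated step of a 6.1-fold higher number from compound 2 to compound 4 (0.78 log units; beyond the scatter) in this assay. The expected value for compound 4 is 60000 nM, estimated between 15000 nM and 250000 nM.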

Compound 4, half-maximal inhibitory concentration: 125000 nM
Compound 4: middle estimate off by 2.1-fold (0.32 log units), on the low side; the range from low to high includes it.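

In this assay, putting hydrogen in place of the chloro on an aromatic carbon again gave a large rise in the number, meaning a weaker inhibitor, with a 13-fold higher number from compound 2 to compound 4 (1.10 log units; beyond the scatter). The direction of the change therefore carried over between the two pairs shown, but its size did not: the same change on two cores in this assay, a 150-fold higher number (2.16 log units; beyond the scatter) from compound 1 to compound 3 and a 13-fold higher number (1.10 log units; beyond the scatter) from compound 2 to compound 4, 11-fold (1.06 log units) apart, beyond the scatter of two such steps

This shows that a step measured on one core cannot simply be copied to another core in this series, though two pairs cannot separate the part played by where the chloro sits from the part played by the other differences between the cores, and they give no rule for predicting the step on a further core.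

The compounds shown leave open how other groups in place of the chloro, such as a methoxy group, an amine or a carboxylic acid, would read. As far as these compounds go, it also remains open whether a longer chain there would keep any of the strength seen with the chloro.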